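Carboxylate tether variation on a shared anilinomethyl-diphenyl-ether core

The source may report more compounds than this note shows. Statements on the series, on what has been measured and on what is new or still open speak of the compounds shown alone.

Compounds with numbers so far:
compound 1, `O=C(O)c1ccc(NCc2cccc(Oc3ccccc3)c2)cc1`, < 10000 nM
compound 2, `O=C(O)CCCc1ccc(NCc2cccc(Oc3ccccc3)c2)cc1`, 1120 nM
compound 3, `O=C(O)COc1ccc(NCc2cccc(Oc3ccccc3)c2)cc1`, 2040 nM

All three share the core shown and differ only in the acid-bearing tether on the aromatic ring. In a functional assay on CHO cells for agonist activity at Free fatty acid receptor 1 (Homo sapiens) (on this read-out lower numbers stand for an effect already at smaller amounts and higher numbers for an effect only at larger amounts of compound), compound 1 gives only a limit, < 10000 nM, and no number. Compound 2 gives 1120 nM in this assay. Compound 3 gives 2040 nM in this assay, the higher of the two numbers, yet the step of a 1.8-fold higher number from compound 2 to compound 3 (0.26 log units; within the scatter) lies within the scatter, so compounds 2 and 3 cannot be separated on these data. The steps from compound 1, a step that the limit leaves unreadable from compound 1 to compound 2 and a step that the limit leaves unreadable from compound 1 to compound 3, cannot be sized because of the limit of < 10000 nM in this assay, at which 1 of the 3 values shown sits.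

Compound 4, `CC(C)(Oc1ccc(NCc2cccc(Oc3ccccc3)c2)cc1)C(=O)O`, carries the change (1-carboxy-1-methylethyl in place of carboxymethyl on an oxygen on an aromatic ring). Within the data shown here, no measured step adds carbon to the tether while keeping the oxygen link, so the only step that bears on it is a 1.8-fold higher number from compound 2 to compound 3 (0.26 log units; within the scatter), which was within the scatter. On that basis no step beyond the scatter is expected, with a 1.3-fold lower number from compound 3 to compound 4 (0.11 log units; within the scatter) as the expected change. Compound 4 is therefore estimated at 1600 nM in this assay, in the range 500 nM to 6000 nM.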

Compound 4, half-maximal effective concentration: < 10000 nM
Compound 4 gave a limit, no number (the forecaster's own chance of this, stated with the estimate: 10%); the middle value does not contradict the limit.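

Compound 4 gives only a limit in this assay, < 10000 nM. The steps to compound 4 from compound 1, compound 2 and compound 3 therefore cannot be read, for one reason: the limit of < 10000 nM in this assay, at which 2 of the 4 values shown sit.

The compounds shown leave open how 1-carboxy-1-methylethyl in place of carboxymethyl on the oxygen shifts the read-out, and where compound 4 and compound 1 stand relative to compound 2 and compound 3.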